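Methyl on the pendant phenyl across two cores

A few compounds are considered here, and "the series" means these few. Any claim that something is new, unique, unknown or untested is made for them only; others in the source may bear on it.

The set pairs two cores. Compound 1 `COc1cc(C(=O)NNC(=S)Nc2csc(-c3ccccc3)c2)cc(OC)c1OC` and compound 2 `COc1cc(C(=O)NNC(=S)Nc2csc(-c3ccc(C)cc3)c2)cc(OC)c1OC` share one core; compound 3 `COc1ccc(C(=O)NNC(=S)Nc2csc(-c3ccccc3)c2)cc1` and compound 4 `COc1ccc(C(=O)NNC(=S)Nc2csc(-c3ccc(C)cc3)c2)cc1` share the other. The difference between the two cores is not broken down here.

In a functional assay on MCF7 cells (Homo sapiens) for inhibition, read by colorimetric assay and MTT assay, with a stated time of 72 h (on this read-out higher numbers stand for weaker inhibition and lower numbers for stronger inhibition), compound 1 gives 43000 nM, and compound 2 gives 31000 nM. The change between them is methyl in place of hydrogen on an aromatic carbon, and it produced a 1.4-fold lower number from compound 1 to compound 2 (0.14 log units; within the scatter). In this assay compound 3 gives 32000 nM; against compound 2 this lies within the scatter, and against compound 1 it lies within the scatter as well.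

Compound 4 differs from compound 3 by methyl in place of hydrogen on an aromatic carbon, the same change as the one from compound 1 to compound 2; it occurs twice in all among these compounds. For the measured compounds named here, only one measured instance of it exists, and that instance stayed within the scatter, so nothing here shows the methyl moving the number one way or the other. For compound 4 the expected step is a 1.3-fold lower number from compound 3 to compound 4 (0.11 log units; within the scatter), of the same size as the earlier one. Going by the values given here, this rests on compound 3 at 32000 nM and on the single observed step of a 1.4-fold lower number from compound 1 to compound 2 (0.14 log units; within the scatter). Compound 4 is therefore estimated at 25000 nM, with a range from 12000 nM to 50000 nM. A number within the scatter of compound 3 is expected to be the most likely outcome.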

Compound 4, half-maximal inhibitory concentration: 5000 nM
Estimate against measurement, compound 4: 5.0-fold (0.70 log units) above, outside the stated range (below it).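

On the core of compound 3, methyl in place of hydrogen on an aromatic carbon gives a 6.4-fold lower number from compound 3 to compound 4 (0.81 log units; beyond the scatter) in this assay, so on this core the change moves the number by more than the usual variation between repeats. For the compounds shown here, the step observed on the core of compound 1 therefore does not carry over in size to this core: the same change on two cores in this assay, a 1.4-fold lower number (0.14 log units; within the scatter) from compound 1 to compound 2 and a 6.4-fold lower number (0.81 log units; beyond the scatter) from compound 3 to compound 4, 4.6-fold (0.66 log units) apart, beyond the scatter of two such steps With only two pairs in a single assay, this shows that the size of the step depends on the core in these four compounds, but it does not show which feature of the core is responsible, and it gives no general rule for how the change will behave on any further core.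

Still open, from the compounds shown here alone, is whether the larger step belongs to the methyl alone or whether the core of compound 3 would respond in the same way to another group at the same place on the pendant phenyl, such as an ethyl, a chlorine or a methoxy. Going by these compounds, it is equally open whether any of these groups would produce a step beyond the usual variation on the core of compound 1, where the methyl did not.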